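Swapping a ring amine for a ring nitrogen link

The source may report more compounds than this note shows. Statements on the series, on what has been measured and on what is new or still open speak of the compounds shown alone.

Of the compounds shown here, two from this series have been tested so far. Compound 1 `O=C(Nc1ncc(C(=O)O)c2nc(-c3ccco3)nn12)NC1CCCCC1`, which carries a free carboxylic acid and a urea, gives in an assay on CHO cells for displacement of a labelled ligand from adenosine receptor A3 (Homo sapiens) (on this read-out lower numbers stand for stronger inhibition and higher numbers for weaker inhibition), a reading of 59400 nM. Compound 2 `CCOC(=O)c1cnc(NC2CCCC2)n2nc(-c3ccco3)nc12`, an ethyl ester with a cyclopentylamino group, gives in this assay a reading of 35 nM, the lowest of the two numbers and far apart from compound 1, a gap well beyond the usual scatter.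

Compound 3 `CCOC(=O)c1cnc(N2CCCCC2)n2nc(-c3ccco3)nc12` has not yet been measured. It differs from compound 2 in a single place: piperidin-1-yl in place of cyclopentylamino on an aromatic carbon. The change keeps the same atoms but rearranges them, and the hydrogen on the nitrogen that linked the ring to the core is gone.

Among the measured compounds shown here, no comparable pair of measured compounds exists to anchor this step. The expectation is a weaker result, with compound 3 estimated at 350 nM, between 70 nM and 3500 nM. That corresponds to an expected step of a 10-fold higher number from compound 2 to compound 3 (1.00 log units; beyond the scatter).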

Compound 3, inhibition constant: 1770 nM
Estimate against measurement, compound 3: 5.1-fold (0.70 log units) below; the range from low to high includes it.
By their numbers in this assay, from the lowest: compound 2; then compound 3; then compound 1.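

Rearranging the same atoms at this position, the aromatic carbon between two ring nitrogen atoms, gives in this assay a 51-fold higher number from compound 2 to compound 3 (1.70 log units; beyond the scatter), so the read-out here depends on how the group is built and not only on which atoms it contains. The change alters two features at once: the ring goes from five-membered and all carbon to six-membered with a ring nitrogen, and the hydrogen-bond donor counted on cyclopentylamino is gone from piperidin-1-yl. No measured evidence is available to explain the weaker binding reading of compound 3.

The compounds shown therefore leave open whether ring size or the nitrogen's hydrogen matters more. A cyclohexylamino group would keep that hydrogen on a six-membered ring, while a pyrrolidin-1-yl group would lack it on a five-membered ring, and these two could help separate the features.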